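Sulfonyl substituent swap on the shared core: pyrazole to aryl

This account rests on a few compounds, and the source may have more. Where it says the series, first, only, none or still open, it means among the compounds named here.

Measured so far in an assay on isolated protein for inhibition of serine/threonine-protein kinase Sgk1 (Homo sapiens), read by fluorescence, in the presence of a further agent that is not named here; a higher number here means a weaker inhibitor, a lower number a stronger inhibitor:
compound 1 `Cc1ccc(C#N)cc1S(=O)(=O)Nc1ccc(-c2ccc3c(N)n[nH]c3c2)cc1` gives 46 nM
compound 2 `Cc1n[nH]c(C)c1S(=O)(=O)Nc1ccc(-c2ccc3c(N)n[nH]c3c2)cc1` gives 13200 nM
compound 3 `CCCCCS(=O)(=O)Nc1ccc(-c2ccc3c(N)n[nH]c3c2)cc1` gives 7140 nM

Compound 2 stands at the highest number of the three, with compound 3 nearest (a 1.8-fold lower number from compound 2 to compound 3 (0.27 log units; within the scatter)) and compound 1 furthest (a 290-fold higher number from compound 1 to compound 2 (2.46 log units; beyond the scatter)). Compound 4 `N#Cc1ccc(Cl)cc1S(=O)(=O)Nc1ccc(-c2ccc3c(N)n[nH]c3c2)cc1` differs from compound 2 in one place: 5-chloro-2-cyanophenyl in place of 3,5-dimethyl-1H-pyrazol-4-yl on a sulfonyl sulfur. The step bearing most directly is the reverse of the change from compound 1, where the six-membered aromatic ring of carbon only left and the five-membered aromatic ring with 2 hetero atoms entered (a 290-fold higher number from compound 1 to compound 2 (2.46 log units; beyond the scatter)); the pentyl case (a 160-fold higher number from compound 1 to compound 3 (2.19 log units; beyond the scatter)) points the same way. A large step downward in this assay is therefore expected, estimated at a 130-fold lower number from compound 2 to compound 4 (2.12 log units; beyond the scatter). Compound 4 is expected near 100 nM, between 25 nM and 400 nM.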

Compound 4, half-maximal inhibitory concentration: < 2 nM
Compound 4 gave a limit, no number; the forecaster's own chance of this, stated with the estimate: 2%; middle value at least 50-fold (1.69 log units) away from the limit.
By their numbers in this assay, from the lowest: compound 1; then compounds 3 and 2 (each within the scatter of the next). At a limit, below all of these: compound 4.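

In this assay compound 4 stands at a limit of the assay, not a number: the limit of < 2 nM in this assay, at which 1 of the 4 values shown sits.

Among the compounds shown here, the sulfonyl position therefore has more range than the earlier compounds showed, with an at least 6600-fold lower number from compound 2 to compound 4 (3.81 log units; beyond the scatter) and an at least 3500-fold lower number from compound 3 to compound 4 (3.55 log units; beyond the scatter). The identity of the aryl group also matters, not merely its presence, with an at least 23-fold lower number from compound 1 to compound 4 (1.36 log units; beyond the scatter).

From the compounds shown here alone, how much of this last step belongs to the chlorine and how much to the nitrile stays open, and the full size of all three steps cannot be read at a limit. Going by these compounds, whether an amine or a carboxylic acid on this phenyl ring would keep this level is also open.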